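Moving the hydroxyl along a propoxy chain

The source may report more compounds than this note shows. Statements on the series, on what has been measured and on what is new or still open speak of the compounds shown alone.

Compound 1 `Cc1ccc(C(=O)Nc2ncc(Cc3cccc(C(F)(F)F)c3)s2)cc1C` gives 8220 nM in an assay on microsomes for inhibition of acyl-CoA desaturase 1 (Mus musculus), with a stated time of 60 min; a higher number here means a weaker inhibitor, a lower number a stronger inhibitor. Compound 2 `COc1ccc(C(=O)Nc2ncc(Cc3cccc(C(F)(F)F)c3)s2)cc1OCCCO` shares the core of compound 1 but carries a methoxy and a 3-hydroxypropoxy group on the benzamide ring; for compound 2 the result in this assay is "not determined" (no result reported), so no number was reported. Compound 3 `COc1ccc(C(=O)Nc2ncc(Cc3cccc(C(F)(F)F)c3)s2)cc1OCC(C)O` differs from compound 2 by 1-hydroxyethyl in place of 2-hydroxyethyl on a saturated chain carbon bound to an oxygen on an aromatic ring. Among the compounds with values here, with no measured step for this kind of change, the expected shift relative to compound 2 is none beyond the scatter, though the anchor is missing. Resting on compound 1, compound 3 is estimated at 6000 nM, within 1500 nM to 25000 nM.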

Compound 3, half-maximal inhibitory concentration: 2170 nM
Beside the measured number, compound 3's estimate is 2.8-fold (0.44 log units) above it, within the range that was stated.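

Within the data shown here, compound 2 has no reported number, so no step to compound 3 can be read from this pair. Nothing available bears on the result. The compounds shown leave open whether changing 3-hydroxypropoxy to 2-hydroxypropoxy shifts inhibition at all.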